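A Fluorophenyl Ring in Place of Pyridin-3-yl

The source may report more compounds than this note shows. Statements on the series, on what has been measured and on what is new or still open speak of the compounds shown alone.

Three compounds sharing one core have been examined in an ADME assay on MT4 cells (Homo sapiens) for cytotoxicity, read by MTT assay, with a stated time of 5 days; on this read-out higher numbers stand for lower toxicity in this test and lower numbers for higher toxicity in this test. Compound 1 `Cc1cc(C#N)cc(C)c1Oc1nc(Nc2ccc(C#N)cc2)ncc1-c1ccsc1` carries a thiophen-3-yl group and gives 3920 nM. Compound 2 `Cc1cc(C#N)cc(C)c1Oc1nc(Nc2ccc(C#N)cc2)ncc1-c1cccc2ccccc12` carries naphthalen-1-yl in the same place, and its result is a limit of the assay, > 267000 nM. Compound 3 `Cc1cc(C#N)cc(C)c1Oc1nc(Nc2ccc(C#N)cc2)ncc1-c1cccnc1` bears pyridin-3-yl and gives 13500 nM, the highest of the two numbers reported; its nearest neighbour is compound 1, reached by a 3.4-fold higher number from compound 1 to compound 3 (0.54 log units; beyond the scatter). The other two steps are far larger: an at least 68-fold higher number from compound 1 to compound 2 (1.83 log units; beyond the scatter) and an at least 19-fold lower number from compound 2 to compound 3 (1.29 log units; beyond the scatter).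

Compound 4 `Cc1cc(C#N)cc(C)c1Oc1nc(Nc2ccc(C#N)cc2)ncc1-c1ccc(F)cc1` has not yet been measured; it differs from compound 3 by 4-fluorophenyl in place of pyridin-3-yl on an aromatic carbon. Within the data shown here, the steps that bear on this change are those that exchanged one aromatic ring for another at that position: the large at least 68-fold higher number from compound 1 to compound 2 (1.83 log units; beyond the scatter) and an at least 19-fold lower number from compound 2 to compound 3 (1.29 log units; beyond the scatter) followed the entry or exit of naphthalen-1-yl, while the modest 3.4-fold higher number from compound 1 to compound 3 (0.54 log units; beyond the scatter) accompanied the exchange of thiophen-3-yl for pyridin-3-yl. The move from pyridin-3-yl to 4-fluorophenyl again swaps one six-membered ring for another, so no more than a small step is expected in this assay, if anything toward a slightly lower number. Compound 4 is therefore estimated at 10000 nM, within 3500 nM to 30000 nM. The implied step, a 1.4-fold lower number from compound 3 to compound 4 (0.13 log units; within the scatter), is expected to stay within the scatter.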

Compound 4, half-maximal cytotoxic concentration: 42700 nM
Compound 4: middle estimate off by 4.3-fold (0.63 log units), on the low side; measured number above the stated range.
By their numbers in this assay, from the lowest: compound 1; then compound 3; then compound 4. At a limit, above all of these: compound 2.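

In this assay, the position does not treat all six-membered aromatic rings alike, as exchanging pyridin-3-yl for 4-fluorophenyl gives a 3.2-fold higher number from compound 3 to compound 4 (0.50 log units; beyond the scatter). The new compound also falls between the earlier extremes, with an 11-fold higher number from compound 1 to compound 4 (1.04 log units; beyond the scatter) and an at least 6.2-fold lower number from compound 2 to compound 4 (0.79 log units; beyond the scatter), so among these four compounds the two rings containing a hetero atom, thiophen-3-yl and pyridin-3-yl, give the lowest numbers and the two carbon-only rings give the highest, with no compound here going against that division. The comparison with compound 2 has an open upper end, as its result is a limit of the assay and not a number: the limit of > 267000 nM in this assay, at which 1 of the 4 values shown sits.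

The step from compound 3 to compound 4 removes the ring nitrogen and adds a fluorine at once, so the compounds shown leave open which of the two changes goes with the higher number, a question an unsubstituted phenyl ring at this position would address. They also leave open how this read-out would respond to a phenyl ring carrying an amine or a carboxylic acid in place of the fluorine.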